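Compound 3 in the antiproliferative series: working notes

The source may report more compounds than this note shows. Statements on the series, on what has been measured and on what is new or still open speak of the compounds shown alone.

compound 1 `COc1ccc2nc(N(Cc3cc(-c4ccc(OC(F)(F)F)cc4)no3)c3nc4ccc(F)cc4s3)sc2c1` — 17400 nM
compound 2 `COc1ccc2nc(N(Cc3cc(-c4ccc(Br)cc4)no3)c3nc4ccc(F)cc4s3)sc2c1` — 41200 nM

Going by the values given here, in a functional assay on MCF7 cells (Homo sapiens) for antiproliferative activity, read by MTT assay (on this read-out higher numbers stand for weaker inhibition and lower numbers for stronger inhibition), compound 2 stands at the highest of the two numbers measured; its nearest neighbour is compound 1, reached through the step of a 2.4-fold higher number from compound 1 to compound 2 (0.37 log units; beyond the scatter), the only measured change so far. Compound 3 `COc1ccc2nc(N(Cc3cc(-c4ccccc4F)no3)c3nc4ccc(F)cc4s3)sc2c1` differs from compound 2 by 2-fluorophenyl in place of 4-bromophenyl on an aromatic carbon. Among the compounds with values here, no measured step covers a 2-fluorophenyl; the single step of a 2.4-fold higher number from compound 1 to compound 2 (0.37 log units; beyond the scatter) exchanged one group for another on the phenyl and was modest, so a change of similar or smaller size is expected here. Compound 3 is expected to show a step of a 1.2-fold lower number from compound 2 to compound 3 (0.07 log units; within the scatter), likely within the scatter. The estimate for compound 3 is 35000 nM, with a range of 12000 nM to 100000 nM.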

Compound 3, half-maximal inhibitory concentration: 28500 nM
Beside the measured number, compound 3's estimate is 1.2-fold (0.09 log units) above it; measured number inside the range.
By their numbers in this assay, from the lowest: compounds 1, 3 and 2 (each within the scatter of the next, the first and the last beyond it).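

At this aromatic carbon, next to the ring nitrogen, 2-fluorophenyl in this assay gives a 1.4-fold lower number from compound 2 to compound 3 (0.16 log units; within the scatter) and a 1.6-fold higher number from compound 1 to compound 3 (0.21 log units; within the scatter). Replacing either earlier substituted phenyl with 2-fluorophenyl thus gives no step beyond the scatter, although the step between the two earlier compounds, a 2.4-fold higher number from compound 1 to compound 2 (0.37 log units; beyond the scatter), lies beyond it. No evidence bears on the reason for these numbers.

As far as these compounds go, whether an amine or a carboxylic acid on the phenyl would give a step beyond the scatter remains open. So does whether 4-fluorophenyl would read differently from 2-fluorophenyl.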